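Methyl Additions and Cytotoxicity in a Sulfonyl Series

The compounds below may be only part of what the source reports. "The series", "measured", "known", "first", "only" and "open" are said of these compounds alone.

Compound 1 `Cc1ccc(S(=O)(=O)n2c(=O)[nH]c3ccc(Cl)cc32)c(C)c1` gives in an ADME assay on MT4 cells (Homo sapiens) for cytotoxicity (on this read-out higher numbers stand for lower toxicity in this test and lower numbers for higher toxicity in this test), a value of 39300 nM. Compound 2 `Cc1cc(C)c(S(=O)(=O)n2c(=O)[nH]c3ccc(Cl)cc32)c(C)c1` differs from it by methyl in place of hydrogen on an aromatic carbon. For compound 2 the read-out in this assay is a limit of the assay, > 356000 nM. The step of an at least 9.0-fold higher number from compound 1 to compound 2 (0.95 log units; beyond the scatter) therefore rests on (the limit of > 356000 nM in this assay, at which 1 of the 3 values shown sits). Compound 3 `Cc1cc(C)c(C)c(S(=O)(=O)n2c(=O)[nH]c3ccc(Cl)cc32)c1C` has a core whose difference from that of compound 1 is not broken down here. In this assay compound 3 also reaches only a limit, >= 342000 nM. Compound 4 `Cc1c(C)c(C)c(S(=O)(=O)n2c(=O)[nH]c3ccc(Cl)cc32)c(C)c1C` is still to be measured; it arises from compound 3 by methyl in place of hydrogen on an aromatic carbon, the same kind of change as that from compound 1 to compound 2, though the place differs: here ortho to two methyl groups, meta to two methyl groups and para to a large group, there ortho to a large group and meta to two methyl groups. Resting on (the limit of >= 342000 nM in this assay, at which 1 of the 3 values shown sits), compound 4 is expected to remain at such a limit, an estimated step that the limit leaves unreadable from compound 3 to compound 4. The estimated value for compound 4 in this assay is 400000 nM, expected between 150000 nM and 1000000 nM.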

Compound 4, half-maximal cytotoxic concentration: 236000 nM
For compound 4 the middle estimate is 1.7-fold (0.23 log units) above the measured one; measured number inside the range.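

In this assay, methyl in place of hydrogen on an aromatic carbon gives an at least 1.4-fold lower number from compound 3 to compound 4 (0.16 log units; that floor lies within the scatter), so the change does not carry over with the same result from the core of compound 1 to the core of compound 3: the same change on two cores in this assay, an at least 9.0-fold higher number (0.95 log units; beyond the scatter) from compound 1 to compound 2 and an at least 1.4-fold lower number (0.16 log units; that floor lies within the scatter) from compound 3 to compound 4, at least 13-fold (1.11 log units) apart, beyond the scatter of two such steps

Compound 2 stands at a limit of the assay, so the earlier step gives only a floor: the limit of > 356000 nM in this assay, at which 1 of the 4 values shown sits.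

Compound 3 also stands at a limit of the assay, so the new step likewise gives only a floor, and the result shows neither the true size of either step nor why they differ: the limit of >= 342000 nM in this assay, at which 1 of the 4 values shown sits.

From the compounds shown here alone, whether a methoxy group, an amine or a chlorine in the same place would follow methyl on these cores remains open. So does whether the difference holds beyond these four compounds.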